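Three Limits, Then a 4-(trifluoromethoxy)phenyl Group

The compounds below may be only part of what the source reports. "The series", "measured", "known", "first", "only" and "open" are said of these compounds alone.

In an ADME assay on RAW264.7 cells (Mus musculus) for cytotoxicity, read by MTT assay, with a stated time of 24 h, in the absence of a further agent (a lower number here means a stronger inhibitor, a higher number a weaker inhibitor), compound 3, with structure `CCOCCOc1ccc(C(O)C2OC(=O)c3c(OC)cc(OC)cc32)cc1`, gives only a limit, > 40000 nM, and not a number. Compound 1, `CCCCOc1ccc(C(O)C2OC(=O)c3c(OC)cc(OC)cc32)cc1`, likewise stops at the limit > 40000 nM. Compound 2, `CCCCCCOc1ccc(C(O)C2OC(=O)c3c(OC)cc(OC)cc32)cc1`, also stops at the limit > 40000 nM. All three therefore stand at the same place, as the limit of > 40000 nM in this assay, at which 3 of the 3 values shown sit, records. The steps among them, a step that the two limits leave unreadable from compound 1 to compound 2, a step that the two limits leave unreadable from compound 1 to compound 3 and a step that the two limits leave unreadable from compound 2 to compound 3, cannot be read in size or direction. Compound 4, `COc1cc(OC)c2c(c1)C(C(O)c1ccc(OCc3ccc(OC(F)(F)F)cc3)cc1)OC2=O`, differs from compound 3 by 4-(trifluoromethoxy)phenyl in place of ethoxymethyl on a saturated chain carbon bound to an oxygen on an aromatic ring; the shared core is untouched. Going by the values given here, none of the measured steps concerns a change of this kind, and none of them offers a readable size to carry over, so nothing in the data points away from the common limit. The expectation is that compound 4 stays where compound 3 sits, and the estimate is 40000 nM, within 15000 nM to 120000 nM, most likely reported again as a limit. The estimated step of a number no higher from compound 3 to compound 4 (the limit leaves the size open) is accordingly expected to be none beyond the scatter.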

Compound 4, half-maximal inhibitory concentration: > 40000 nM
Compound 4: only a limit was reported; the forecaster's own chance of this, stated with the estimate: 80%; the middle value sits exactly at the limit.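

Compound 4 also gives only a limit, > 40000 nM, so its steps from compound 1, compound 2 and compound 3 cannot be read in size or direction. The compounds shown leave open whether changing this side chain shifts the result in this assay at all.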